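A few compounds are considered here, and "the series" means these few. Any claim that something is new, unique, unknown or untested is made for them only; others in the source may bear on it.

Compound 1 `Cc1ccc(-c2n[nH]c(-c3ccccc3)n2)c(C)c1` gives 0.2 mg/kg in a functional assay on the whole organism (Cricetulus griseus) with Cricetinae gen. sp. as the target; on this read-out higher numbers stand for an effect only at larger amounts of compound and lower numbers for an effect already at smaller amounts. Compound 2 `COc1ccc(-c2n[nH]c(-c3ccccc3)n2)c(C)c1` differs from it by methoxy in place of methyl on an aromatic carbon. In this assay compound 2 reaches only the limit > 10 mg/kg, which is not a number. That change brought an at least 50-fold higher number from compound 1 to compound 2 (1.69 log units; beyond the scatter). Compound 3 `Cc1ccc(C)c(-c2n[nH]c(-c3ccccc3)n2)c1` is built from the same atoms as compound 1, joined differently; the difference between the two cores is not broken down here. In this assay compound 3 likewise gives only the limit > 10 mg/kg. Compound 4 `COc1ccc(C)c(-c2n[nH]c(-c3ccccc3)n2)c1` has not yet been measured; it differs from compound 3 by methoxy in place of methyl on an aromatic carbon, the same kind of change as before, though now the place is meta to a large group and para to a methyl group rather than meta to a methyl group and para to a large group. Beside an at least 50-fold higher number from compound 1 to compound 2 (1.69 log units; beyond the scatter), the expected step is a step that the limit leaves unreadable from compound 3 to compound 4, because the limit of > 10 mg/kg in this assay, at which 2 of the 3 values shown sit, is where compound 3 already stands. Compound 4 is therefore estimated at 30 mg/kg in this assay.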

Compound 4, dose for half-maximal effect: > 10 mg/kg
Compound 4 was reported as a limit; the forecaster's own chance of this, stated with the estimate: 85%; the middle value lies beyond the limit too.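

No step can be read between compound 3 and compound 4, since both are reported only as a limit and not as a number: the limit of > 10 mg/kg in this assay, at which 3 of the 4 values shown sit.

The compounds shown leave open whether methoxy in place of methyl changes the result in this assay at this place, meta to a large group and para to a methyl group.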